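The source may report more compounds than this note shows. Statements on the series, on what has been measured and on what is new or still open speak of the compounds shown alone.

Among the compounds with values here, in a functional assay on ZR-75-1 cells (Homo sapiens) for inhibition, read by sulforhodamine B assay (a lower number here means a stronger inhibitor of growth, a higher number a weaker inhibitor of growth), compound 3 `Cc1ccc2[nH]c(-c3ccc(-c4ccc(-c5ccc(F)cc5)cc4)cc3)nc2c1` gives 35000 nM, the middle of the three numbers so far. Compound 1 `Cc1ccc2[nH]c(-c3ccc(-c4ccc(-c5cccc(Cl)c5)cc4)cc3)nc2c1` sits lower at 3450 nM, and compound 2 `Oc1ccc(-c2ccc(-c3ccc(-c4nc5ccccc5[nH]4)cc3)cc2)cc1` sits higher at 100000 nM, both beyond the scatter from compound 3.

Compound 4 `Cc1ccc2[nH]c(-c3ccc(-c4ccc(-c5ccc(O)cc5)cc4)cc3)nc2c1` keeps the core of compound 3 and changes one group, with hydroxy in place of fluoro on an aromatic carbon. Within the data shown here, no measured pair isolates this exact swap. Among the measured compounds shown here, the one measured step that touches this group, 4-fluorophenyl in place of 3-chlorophenyl, gave a 10-fold higher number from compound 1 to compound 3 (1.01 log units; beyond the scatter), a large step, so changing the group here can move the number a long way. That step involves no hydroxy group, however, so it says little about direction. The core of compound 3 is not identical to that of compound 2, but the best guide to direction is still compound 2, which also carries 4-hydroxyphenyl and gives 100000 nM.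

A modest move toward weaker growth inhibition in this assay is therefore expected, a 1.7-fold higher number from compound 3 to compound 4 (0.23 log units; within the scatter). For compound 4 the estimated value is 60000 nM, with an expected range from 20000 nM to 120000 nM.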

Compound 4, concentration for 50% growth inhibition: 18200 nM
For compound 4 the middle estimate is 3.3-fold (0.52 log units) above the measured one; the measured number lies below the stated range.
By their numbers in this assay, from the lowest: compound 1; then compounds 4 and 3 (each within the scatter of the next); then compound 2.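

In this assay, within the data shown here, the first direct comparison at this position does not separate the two groups: the swap of fluoro for hydroxy gives a 1.9-fold lower number from compound 3 to compound 4 (0.28 log units; within the scatter). The methyl group on the core, by contrast, has a visible effect when it is the only difference, with a 5.5-fold lower number from compound 2 to compound 4 (0.74 log units; beyond the scatter). With a 5.3-fold higher number from compound 1 to compound 4 (0.72 log units; beyond the scatter) beside a 10-fold higher number from compound 1 to compound 3 (1.01 log units; beyond the scatter), the large shifts at this end of the molecule come with leaving 3-chlorophenyl, while the choice between 4-fluorophenyl and 4-hydroxyphenyl makes no difference beyond the scatter.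

On these data alone, what an amine or a carboxylic acid would do in place of fluoro or hydroxy on this ring remains open, as does whether other groups could match 3-chlorophenyl. Nothing available here explains why fluoro and hydroxy read alike.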